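This account rests on a few compounds, and the source may have more. Where it says the series, first, only, none or still open, it means among the compounds named here.

Compound 1 `O=c1ccoc2cc(OCc3cn(Cc4ccccc4)nn3)ccc12`: in a functional assay on SW480 cells (Homo sapiens) for cytotoxicity, read by MTT assay, with a stated time of 48 h (a higher number here means a weaker inhibitor, a lower number a stronger inhibitor), compound 1 gives 42900 nM. Compound 2 `Cc1ccccc1Cn1cc(COc2ccc3c(=O)ccoc3c2)nn1`: in this assay compound 2 reaches only a limit of the assay, > 100000 nM.

Compound 2 therefore stands at the limit of > 100000 nM in this assay, at which 1 of the 2 values shown sits, with no number of its own. The step from compound 1 to compound 2 was an at least 2.3-fold higher number from compound 1 to compound 2 (0.36 log units; beyond the scatter). Compound 3 `O=c1ccoc2cc(OCc3cn(Cc4ccc(Cl)cc4Cl)nn3)ccc12` differs from compound 2 by 2,4-dichlorophenyl in place of 2-methylphenyl on a saturated chain carbon bound to an aromatic nitrogen. For the measured compounds named here, no measured step covers chlorine on this ring. Going by the values given here, the only step that bears on a change to the benzyl group, an at least 2.3-fold higher number from compound 1 to compound 2 (0.36 log units; beyond the scatter), weakened inhibition. Compound 3 is therefore expected to remain near the limit, giving a number no higher from compound 2 to compound 3 (the limit leaves the size open) in this assay. Compound 3 is estimated at 100000 nM, in a range from 30000 nM to 300000 nM.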

Compound 3, half-maximal inhibitory concentration: > 100000 nM
Compound 3 gave a limit, no number; the forecaster's own chance of this, stated with the estimate: 60%; the middle value lies on the limit itself.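

On the group carried by the saturated chain carbon, 2,4-dichlorophenyl in place of phenyl also weakens inhibition, with an at least 2.3-fold higher number from compound 1 to compound 3 (0.36 log units; beyond the scatter). The loss in this assay is therefore not confined to the 2-methylphenyl group of compound 2, and chlorine on this ring brings no gain over compound 1. Compound 2 and compound 3 both stand at a limit, so the step between them cannot be read: the limit of > 100000 nM in this assay, at which 2 of the 3 values shown sit.

Left open is whether an amine or a carboxylic acid on this ring would give a number rather than a limit. Also open, from the compounds shown here alone, is whether a single chlorine would behave as the 2,4-dichlorophenyl group does.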